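Retinal dehydrogenase 2 series: phenyl in place of 4-ethynylphenyl

A few compounds are considered here, and "the series" means these few. Any claim that something is new, unique, unknown or untested is made for them only; others in the source may bear on it.

Of the compounds shown here, three of the shared core have been measured so far. In an assay on isolated protein for inhibition of retinal dehydrogenase 2 (Homo sapiens) (on this read-out higher numbers stand for weaker inhibition and lower numbers for stronger inhibition), compound 1 `Cn1ncc2c(=O)n(-c3ccccc3)c(SC(C)(C)c3ccccc3)nc21` gives 2200 nM, compound 2 `COc1cccc(C(C)Sc2nc3c(cnn3C)c(=O)n2-c2ccccc2)c1` gives 108 nM, and compound 3 `C#Cc1ccc(-n2c(SC(C)c3ccccc3)nc3c(cnn3C)c2=O)cc1` gives 800 nM. Compound 3 holds the second highest of the three numbers: compound 1 sits nearest, with a higher number beyond the scatter, and compound 2 sits furthest, with a lower number beyond the scatter.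

Compound 4 `CC(Sc1nc2c(cnn2C)c(=O)n1-c1ccccc1)c1ccccc1` has not been measured. Relative to compound 3 the change is hydrogen in place of ethynyl on an aromatic carbon, read one bond further out as 4-ethynylphenyl to phenyl. Going by the values given here, no measured pair isolates this change. Both compound 1 and compound 2 carry a plain phenyl on the ring nitrogen: compound 1 reaches 2200 nM and compound 2 reaches 108 nM, so the plain phenyl is compatible with the whole span seen so far and the benzylic side appears to decide more. The expected step for this change, a 1.6-fold lower number from compound 3 to compound 4 (0.20 log units; within the scatter), should stay within the scatter or go a little lower. Compound 4 is estimated at 500 nM, with a range of 150 nM to 1600 nM.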

Compound 4, half-maximal inhibitory concentration: 110 nM
Beside the measured number, compound 4's estimate is 4.5-fold (0.66 log units) above it; measured number outside the range, below it.
By their numbers in this assay, from the lowest: compounds 2 and 4 (each within the scatter of the next); then compound 3; then compound 1.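

In this assay the first matched read on this position is a 7.3-fold lower number from compound 3 to compound 4 (0.86 log units; beyond the scatter) and so the ethynyl, para to a large group, goes with a clearly higher number than hydrogen in this pair. Hydrogen in place of methoxy on an aromatic carbon gives a 1.0-fold higher number from compound 2 to compound 4 (0.01 log units; within the scatter) and leaves no readable difference, so this ethynyl step stands apart from the methoxy one, though the two lie on different aromatic rings. Hydrogen in place of methyl on the saturated chain carbon bound to an aromatic carbon, a saturated chain carbon and a sulfur gives a 20-fold lower number from compound 1 to compound 4 (1.30 log units; beyond the scatter) and is the largest of the three steps.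

Nothing shown here explains any of these steps. From the compounds shown here alone, whether a smaller group such as fluorine or methyl, or a nitrile or an amine, on that same aromatic carbon stays close to hydrogen or moves towards ethynyl remains open.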